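A few compounds are considered here, and "the series" means these few. Any claim that something is new, unique, unknown or untested is made for them only; others in the source may bear on it.

In a functional assay (aorta) with Rattus norvegicus as the target (a lower number here means a stronger inhibitor, a higher number a weaker inhibitor), compound 1 (`CC(=O)c1ccc(N/C(=N/[C@@H]2c3cc(C#N)ccc3OC(C)(C)[C@H]2O)NC#N)cc1`) gives 21000 nM as a measured number. Compound 2 (`CC1(C)Oc2ccc(C#N)cc2[C@@H](/N=C(\NC#N)Nc2cccc(C(=O)O)c2)[C@@H]1O`) gives > 100000 nM and this is a limit of the assay, not a number. The record for compound 2 therefore holds only the limit of > 100000 nM in this assay, at which 1 of the 2 values shown sits, and no exact standing. Among the measured compounds shown here, the one measured step is an at least 4.7-fold higher number from compound 1 to compound 2 (0.67 log units; beyond the scatter) and it comes with 3-carboxyphenyl in place of 4-acetylphenyl on an amine nitrogen.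

Compound 3 (`Cc1ccc(N/C(=N/[C@@H]2c3cc(C#N)ccc3OC(C)(C)[C@H]2O)NC#N)cc1`) carries the next change, 4-methylphenyl in place of 3-carboxyphenyl on an amine nitrogen with 4-methylphenyl in place of 3-carboxyphenyl on an amine nitrogen. The measured step bears on this one when read backwards, since the 3-carboxyphenyl leaves again. A lower number is therefore expected in this assay by an amount at least comparable to that step and beyond the scatter. For the measured compounds named here, compound 1 at 21000 nM is the nearest guide, although no measured step compares 4-methylphenyl with 4-acetylphenyl. The expected change is an at least 8.3-fold lower number from compound 2 to compound 3 (0.92 log units; beyond the scatter) on this estimate. For compound 3 the expected value is 12000 nM with an estimated range from 2500 nM to 60000 nM in this assay.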

Compound 3, half-maximal inhibitory concentration: 2700 nM
Beside the measured number, compound 3's estimate is 4.4-fold (0.65 log units) above it; low and high end bracket the measured number.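

Within the 4-substituted pair, the aryl group on the amine nitrogen proves to be a site where a small change counts in this assay: methyl in place of acetyl on an aromatic carbon gives a 7.8-fold lower number from compound 1 to compound 3 (0.89 log units; beyond the scatter). So the earlier loss with 3-carboxyphenyl is not the only sizeable effect at this nitrogen, and 4-methylphenyl gives the lowest number of the series, with an at least 37-fold lower number from compound 2 to compound 3 (1.56 log units; beyond the scatter) as the widest step shown. Compound 2 holds only a limit of the assay, so the size of that widest step remains open-ended: the limit of > 100000 nM in this assay, at which 1 of the 3 values shown sits.

The step to 4-methylphenyl also swaps the substituent and its number on the ring at once, so the compounds shown do not separate these two parts of the change; 3-methylphenyl and 4-carboxyphenyl would do so. Going by these compounds, whether the methyl itself lowers the number or the acetyl raises it stays open too, a question that an unsubstituted phenyl would address, while 4-ethylphenyl or 4-methoxyphenyl would show how far the trend from acetyl to methyl extends.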